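The compounds below may be only part of what the source reports. "The series", "measured", "known", "first", "only" and "open" are said of these compounds alone.

Measured compounds:
- compound 1, `COc1cc(-c2ccnc3cc(-c4ccc(F)cc4)nn23)cc(OC)c1OC`: 1280 nM
- compound 2, `COc1cc(-c2ccnc3cc(-c4ccc(Cl)cc4)nn23)cc(OC)c1OC`: 2320 nM
- compound 3, `COc1cc(-c2ccnc3cc(-c4ccccc4)nn23)cc(OC)c1OC`: 254 nM

In a functional assay on MCF7 cells (Homo sapiens) for inhibition, read by CCK-8 assay, with a stated time of 48 h (on this read-out higher numbers stand for weaker inhibition and lower numbers for stronger inhibition), compound 1 gives 1280 nM, the second highest of the three numbers. Its nearest neighbour is compound 2, and the change a 1.8-fold higher number from compound 1 to compound 2 (0.26 log units; within the scatter) is within the scatter. The furthest is compound 3, reached by a 5.0-fold lower number from compound 1 to compound 3 (0.70 log units; beyond the scatter), a modest step that goes beyond the scatter; likewise a 9.1-fold lower number from compound 2 to compound 3 (0.96 log units; beyond the scatter).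

Compound 4, `COc1cc(-c2ccnc3cc(-c4cn(C)c5ccccc45)nn23)cc(OC)c1OC`, has not yet been measured in this assay. It differs from compound 1 by 1-methyl-1H-indol-3-yl in place of 4-fluorophenyl on an aromatic carbon.

The measured steps only concern the substituent on the phenyl ring, where removing the halogen lowered the number; none of them exchanges the whole ring for a bicyclic group, so they bear on this change only loosely. Compound 1 is therefore expected to change by a 1.6-fold lower number from compound 1 to compound 4 (0.20 log units; within the scatter) in this assay, with wide uncertainty in both directions. The estimate for compound 4 in this assay is 800 nM, expected between 200 nM and 3500 nM.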

Compound 4, half-maximal inhibitory concentration: 95 nM
Compound 4: middle estimate off by 8.4-fold (0.93 log units), on the high side; measured number below the stated range.
By their numbers in this assay, from the lowest: compound 4; then compound 3; then compounds 1 and 2 (each within the scatter of the next).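

In this assay, the position on the five-membered aromatic ring accepts a fused bicyclic group and does so with a clear gain: 1-methyl-1H-indol-3-yl gives a 13-fold lower number from compound 1 to compound 4 (1.13 log units; beyond the scatter) against the 4-fluorophenyl group and a 24-fold lower number from compound 2 to compound 4 (1.39 log units; beyond the scatter) against the 4-chlorophenyl group. The change also goes beyond removing a halogen, since the plain phenyl group, previously the lowest number, is passed by a 2.7-fold lower number from compound 3 to compound 4 (0.43 log units; beyond the scatter) and compound 4 now stands lowest of the four. Nothing available explains why this group outperforms the phenyl groups.

Which part of the group carries the gain remains open: the ring nitrogen, its methyl or the second ring. On these data alone, how 1H-indol-3-yl without the methyl, naphthyl, or a phenyl bearing an amine or methoxy would stand here also remains unknown.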